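This account rests on a few compounds, and the source may have more. Where it says the series, first, only, none or still open, it means among the compounds named here.

Two compounds of the series have numbers in an assay on Sf9 cells for inhibition of mitogen-activated protein kinase kinase kinase 14 (Homo sapiens), read by ADP-Glo, with a stated time of 60 min; a higher number here means a weaker inhibitor, a lower number a stronger inhibitor. Compound 1 `Cc1n[nH]c(N)c1-c1ccc(Cl)cc1` gives 61100 nM. Compound 2 `CC(=O)n1nc(C)c(-c2ccc(Cl)c(Cl)c2)c1N` gives 8400 nM, the lower of the two numbers, with compound 1 the nearest at a gap beyond the usual scatter. Within the data shown here, compound 1 and compound 2 differ in more than one place, so no single structural step is separated by the measurements so far. Compound 3 `CC(=O)n1nc(C)c(-c2ccc(Cl)cc2)c1N` differs from compound 2 by hydrogen in place of chloro on an aromatic carbon. Among the measured compounds shown here, with no measured step to lean on, a modest move toward a higher number is expected for compound 3, estimated at 15000 nM with a range of 6000 nM to 40000 nM. The expected step is a 1.8-fold higher number from compound 2 to compound 3 (0.25 log units; within the scatter).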

Compound 3, half-maximal inhibitory concentration: > 100000 nM
Compound 3 was reported as a limit (the forecaster's own chance of this, stated with the estimate: 5%); at least 6.6-fold (0.82 log units) between middle value and limit.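

Among these compounds, removing the chloro ortho to a chloro group is the first single-place change that can be read, and it gives an at least 11-fold higher number from compound 2 to compound 3 (1.07 log units; beyond the scatter) on the acetyl-bearing core. In this assay compound 3 is a limit, not a number: the limit of > 100000 nM in this assay, at which 1 of the 3 values shown sits. Acetyl in place of hydrogen on the aromatic nitrogen gives an at least 1.6-fold higher number from compound 1 to compound 3 (0.21 log units; that floor lies within the scatter) as a floor only, so the size of that step remains unread.

Still open, as far as these compounds go, is whether bromo, methyl or methoxy at the chloro position would match chloro. Also open, from the compounds shown here alone, is whether a propionyl group in place of acetyl would alter the number.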